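The source may report more compounds than this note shows. Statements on the series, on what has been measured and on what is new or still open speak of the compounds shown alone.

Going by the values given here, in a functional assay on A549 cells (Homo sapiens) for cytotoxicity, read by resazurin assay (a higher number here means a weaker inhibitor, a lower number a stronger inhibitor), none of the compounds tested so far gives a number. Compound 1 (`C=C1CC[C@]2(C[C@@H]1O)C(=C)C[C@H](O)[C@@H](Br)C2(C)C`) reads >= 10000 nM, which is a limit of the assay. Compound 2 (`CC1=C[C@H](O)CC(C)(C)[C@]12CC[C@](C)(Br)[C@H](Cl)C2`) reads >= 10000 nM, also a limit. Compound 3 (`CC1=CC(=O)CC(C)(C)[C@@]12C=C/C(=C/Br)CC2`) reads >= 10000 nM, again a limit. All three therefore sit at the limit of >= 10000 nM in this assay, at which 3 of the 3 values shown sit. Compound 4 (`CC1=CC(=O)CC(C)(C)[C@@]12C=C/C(=C\Br)CC2`) has the same atoms and bonds as compound 3: the two compounds have the same atoms and bonds and differ only in configuration as drawn: 1 of 2 stereo elements differ; a double bond is drawn E in compound 3 and Z in compound 4. Among the compounds with values here, no measured step shows what such a change does in this assay, so no change beyond the scatter is expected, in either direction. The estimated step, a number no higher from compound 3 to compound 4 (the limit leaves the size open), is expected to stay within that scatter. Compound 4 is expected at 10000 nM, with an estimated range from 4000 nM to 30000 nM.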

Compound 4, half-maximal inhibitory concentration: >= 10000 nM
Compound 4: a limit, no number (the forecaster's own chance of this, stated with the estimate: 80%); the middle value sits exactly at the limit.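

Going by these compounds alone, compound 3 and compound 4 both read as limits rather than numbers, so no step between them can be read. The compounds shown leave open whether the configuration of the double bond affects activity at all.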